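Replacing the Sulfonamide Nitrogen with a Phenyl Sulfone

The compounds below may be only part of what the source reports. "The series", "measured", "known", "first", "only" and "open" are said of these compounds alone.

Compound 1 `NS(=O)(=O)c1ccc(NC(=O)NCc2ccncc2)cc1` gives 14300 nM in an assay on isolated protein for activation of Nicotinamide phosphoribosyltransferase (Homo sapiens); a higher number here means that more compound is needed for the effect, a lower number that less compound is needed. Among the measured compounds shown here, compound 2 `CCN(C1CCCC1)S(=O)(=O)c1ccc(NC(=O)NCc2ccncc2)cc1` gives 60 nM, the lowest of the two numbers so far; the step of a 240-fold lower number from compound 1 to compound 2 (2.38 log units; beyond the scatter) is the only one measured. Compound 3 `O=C(NCc1ccncc1)Nc1ccc(S(=O)(=O)c2ccccc2)cc1` differs from compound 2 by phenyl in place of cyclopentyl(ethyl)amino on a sulfonyl sulfur. For the measured compounds named here, that large measured step shows that what sits on the sulfonyl sulfur matters greatly, but no measured step tests a carbon ring in that place, so compound 3 is expected to land between the two, with an estimated loss of a 5.0-fold higher number from compound 2 to compound 3 (0.70 log units; beyond the scatter) and a value near 300 nM, plausibly from 60 nM to 1500 nM.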

Compound 3, half-maximal effective concentration: 85 nM
The estimate for compound 3 lay 3.5-fold (0.55 log units) above the measured number; the range from low to high includes it.
By their numbers in this assay, from the lowest: compounds 2 and 3 (each within the scatter of the next); then compound 1.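

In this assay the sulfonyl sulfur does not need a nitrogen attached to it: phenyl in place of cyclopentyl(ethyl)amino gives a 1.4-fold higher number from compound 2 to compound 3 (0.15 log units; within the scatter) and leaves the two groups indistinguishable. Phenyl in place of amino gives a 170-fold lower number from compound 1 to compound 3 (2.23 log units; beyond the scatter) and so recovers a gain of the same large kind as the earlier step, which therefore does not depend on that nitrogen in these compounds. Nothing available explains why these two different groups perform alike.

Still open, as far as these compounds go, is whether a small methyl or a saturated cyclohexyl ring on the sulfonyl sulfur would serve as well. From the compounds shown here alone, it is also open whether a phenyl carrying a fluorine or a methoxy group would change the number beyond the scatter.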